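Fluoro-to-hydrogen swap on two cores: cytotoxicity notes

The source may report more compounds than this note shows. Statements on the series, on what has been measured and on what is new or still open speak of the compounds shown alone.

Four compounds are compared in one measure, an ADME assay on Vero cells (Chlorocebus sabaeus) for cytotoxicity, read by MTT assay, with a stated time of 72 h; a lower number here means that less compound is tolerated, a higher number that more compound is tolerated. Compound 1 `C=CCN(CC=C)C(=S)N/N=C(/C)c1ccccc1` gives 229000 nM in this assay. Compound 2 `C=CCN(CC=C)C(=S)N/N=C(/C)c1ccc(F)cc1` gives 214000 nM in this assay. The pair differs by one change, (hydrogen in place of fluoro on an aromatic carbon), and the measured step is a 1.1-fold higher number from compound 2 to compound 1 (0.03 log units; within the scatter).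

Compound 3 `C/C(=N/NC(=S)N(Cc1ccccc1)Cc1ccccc1)c1ccc(F)cc1` gives 160000 nM in this assay. Its core is not that of compound 2; the difference between the two cores is not broken down here. The value of compound 3 and the value of compound 2 lie within the scatter of each other, as do the values of compound 3 and compound 1, so no ordering among the three measured compounds is claimed.

Compound 4 `C/C(=N/NC(=S)N(Cc1ccccc1)Cc1ccccc1)c1ccccc1` is not yet measured. It stands to compound 3 as compound 1 stands to compound 2: the change is hydrogen in place of fluoro on an aromatic carbon, made at the same place on the ring, so this is the same change on the other core. Among the compounds shown this change occurs twice in all, once measured and once pending.

Among the measured compounds shown here, the only guide for compound 4 is the measured step from compound 2 to compound 1, which stayed within the scatter. The step from compound 3 to compound 4 is therefore expected to be a 1.1-fold higher number from compound 3 to compound 4 (0.04 log units; within the scatter), because a 1.1-fold higher number from compound 2 to compound 1 (0.03 log units; within the scatter) on the other core was small. Compound 4 is expected to give about 175000 nM in this assay, with a likely range from 100000 nM to 300000 nM.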

Compound 4, half-maximal cytotoxic concentration: 167000 nM
The estimate for compound 4 lay 1.0-fold (0.02 log units) above the measured number, within the range that was stated.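

In this assay, the change from 4-fluorophenyl to phenyl on the core of compound 3 gives a 1.0-fold higher number from compound 3 to compound 4 (0.02 log units; within the scatter), so the replacement of fluoro by hydrogen again leaves a step within the scatter. Set beside the earlier step, the change carries from one core to the other without a difference between the two steps that can be told apart: the same change on two cores in this assay, a 1.1-fold higher number (0.03 log units; within the scatter) from compound 2 to compound 1 and a 1.0-fold higher number (0.02 log units; within the scatter) from compound 3 to compound 4, 1.0-fold (0.01 log units) apart, within the scatter of two such steps. This shows agreement on two cores only, and since neither step rises above the scatter, it is agreement between two null results; it does not show that a larger step would carry between cores in the same way, nor does it support a rule for any other core.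

Open, going by these compounds, is whether a different group on that aromatic carbon, such as a carboxylic acid, an amine or a methoxy group, would give a step beyond the scatter in this assay, and whether such a step would hold on both cores. Also open, on these data alone, is whether a longer chain, in place of the groups that set the two cores apart, would shift the number or alter how the fluoro-to-hydrogen change reads.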